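This account rests on a few compounds, and the source may have more. Where it says the series, first, only, none or still open, it means among the compounds named here.

Measured compounds:
compound 1, `Cc1nnc2nnc(N3CCCC3)nn12`, giving 44800 nM in a functional assay on MCF7 cells (Homo sapiens) for cytotoxicity, read by MTT assay, with a stated time of 72 h; a higher number here means a weaker inhibitor, a lower number a stronger inhibitor
compound 2, `c1ccc(-c2nnc3nnc(N4CCCC4)n3n2)cc1`, giving > 100000 nM in this assay, a limit of the assay and not a number

Compound 1 therefore stands as the only number shown in this assay, with 44800 nM. The result for compound 2 is a limit of the assay, > 100000 nM. One of the two values sits at that limit (the limit of > 100000 nM in this assay, at which 1 of the 2 values shown sits).

Compound 3, `CCCCCc1nnc2nnc(N3CCCC3)nn12`, has not yet been measured. It differs from compound 1 by butyl in place of hydrogen on a saturated chain carbon bound to an aromatic carbon. For the measured compounds named here, no step between measured compounds is available to size such a change, so the expectation rests on compound 1 alone. The expected step is a 1.5-fold lower number from compound 1 to compound 3 (0.17 log units; within the scatter), a slight move toward stronger inhibition that may well remain within the scatter. For compound 3 in this assay the estimate is 30000 nM, expected to fall between 8000 nM and 100000 nM.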

Compound 3, half-maximal inhibitory concentration: 42900 nM
Compound 3: the middle estimate sits 1.4-fold (0.16 log units) below what was measured; the range from low to high includes it.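

In this assay, replacing hydrogen with butyl on a saturated chain carbon bound to an aromatic carbon, which turns methyl into pentyl, leaves the number essentially unchanged: a 1.0-fold lower number from compound 1 to compound 3 (0.02 log units; within the scatter). For the compounds shown here, this is the first sized step at this place, and it shows that the longer chain is accommodated here without a change that can be told from the scatter. Nothing among the results shown accounts for why this change has so little effect.

As far as these compounds go, it remains open whether a still longer chain, or a chain ending in an amine or a carboxylic acid, would move the number beyond the scatter. Going by these compounds alone, compound 2 gives > 100000 nM, a limit of the assay and not a number, so no step to it can be read.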